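The compounds below may be only part of what the source reports. "The series", "measured", "known", "first", "only" and "open" are said of these compounds alone.

Compound 1 `O=C1CCC(N2C(=O)C(c3ccccc3)=C(c3ccccc3)C2=O)C(=O)N1` carries a 2,6-dioxopiperidin-3-yl group on the amide-type nitrogen of its five-membered core, which also bears two phenyl groups. In a functional assay on ST486 cells (Homo sapiens) for cytotoxicity, read by MTT assay (on this read-out lower numbers stand for stronger inhibition and higher numbers for weaker inhibition), compound 1 gives > 50000 nM, which is a limit of the assay rather than a measured number. Compound 2 `CN(C)CCN1C(=O)CCC(N2C(=O)C(c3ccccc3)=C(c3ccccc3)C2=O)C1=O` differs by a 2-(dimethylamino)ethyl in place of hydrogen on an amide-type nitrogen in a ring. In this assay compound 2 gives > 50000 nM, again only a limit. The step that the two limits leave unreadable from compound 1 to compound 2 therefore cannot be read, since (the limit of > 50000 nM in this assay, at which 2 of the 2 values shown sit). Compound 3 `NC(=O)CCC(C(=O)O)N1C(=O)C(c2ccccc2)=C(c2ccccc2)C1=O` differs from compound 1 in that (3-carbamoyl-1-carboxypropyl in place of 2,6-dioxopiperidin-3-yl on an amide-type nitrogen in a ring). For the measured compounds named here, no measured step bears directly on this change, and the single comparison at hand is itself unreadable, so nothing points to a potency beyond the scatter in either direction. Compound 3 is expected to remain at the limit, giving a step that the limit leaves unreadable from compound 1 to compound 3 that would not be readable. The estimate for compound 3 is 90000 nM, with a range from 25000 nM to 300000 nM.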

Compound 3, half-maximal inhibitory concentration: > 50000 nM
Compound 3: a limit, no number; the forecaster's own chance of this, stated with the estimate: 80%; the middle value does not contradict the limit.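

In this assay compound 3 gives > 50000 nM, a limit and not a measured number, so the change from compound 1 to compound 3 cannot be read: the limit of > 50000 nM in this assay, at which 3 of the 3 values shown sit. As far as these compounds go, how strongly compound 1, compound 2 and compound 3 each act in this cell assay, and whether they differ at all, remains open.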